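Same sulfur substituent swap carried onto a second core

The compounds below may be only part of what the source reports. "The series", "measured", "known", "first", "only" and "open" are said of these compounds alone.

Measured so far in a functional assay on PC-3 cells (Homo sapiens) for inhibition, read by MTT assay, with a stated time of 48 h; on this read-out higher numbers stand for weaker inhibition and lower numbers for stronger inhibition:
compound 1, `C=C1CC[C@@H]2[C@](C)(CO)[C@H](O)CC[C@@]2(C)[C@@H]1CC(Sc1ccc(F)cc1)C1=CCOC1=O`, gives 16000 nM
compound 2, `C=C1CC[C@@H]2[C@](C)(CO)[C@H](O)CC[C@@]2(C)[C@@H]1CC(Sc1cccs1)C1=CCOC1=O`, gives 15000 nM
compound 3, `C=C1CC[C@@H]2[C@](C)(CO)[C@H](O)CC[C@@]2(C)[C@@H]1C/C=C1/C(=O)OC[C@H]1OC(=O)CSc1ccc(F)cc1`, gives 14000 nM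

Compound 2 differs from compound 1 by one change, (thiophen-2-yl in place of 4-fluorophenyl on a sulfur). This change gives a 1.1-fold lower number from compound 1 to compound 2 (0.03 log units; within the scatter), so the two values cannot be told apart. Compound 3 is built on a different core; the difference between the core of compound 1 and the core of compound 3 is not broken down here. The values of compound 1 and compound 3 are within the scatter of each other in this assay, as are those of compound 2 and compound 3.

Compound 4, `C=C1CC[C@@H]2[C@](C)(CO)[C@H](O)CC[C@@]2(C)[C@@H]1C/C=C1/C(=O)OC[C@H]1OC(=O)CSc1cccs1`, has not yet been measured in this assay. It differs from compound 3 by thiophen-2-yl in place of 4-fluorophenyl on a sulfur, which is the same change as that from compound 1 to compound 2, on the same place. The expected step is a 1.1-fold lower number from compound 3 to compound 4 (0.03 log units; within the scatter), resting on a 1.1-fold lower number from compound 1 to compound 2 (0.03 log units; within the scatter), which was within the scatter. Compound 4 is therefore expected to give about 13000 nM, with an estimated range from 6000 nM to 30000 nM.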

Compound 4, half-maximal inhibitory concentration: 18000 nM
Compound 4: middle estimate off by 1.4-fold (0.14 log units), on the low side; the measured number falls inside the stated range.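

In this assay, putting thiophen-2-yl in place of 4-fluorophenyl on the sulfur gives a 1.3-fold higher number from compound 3 to compound 4 (0.11 log units; within the scatter) on this second core as well, so the two groups cannot be told apart here either. Set beside the step on the first core, the change carries over without any detectable difference between the two cores: the same change on two cores in this assay, a 1.1-fold lower number (0.03 log units; within the scatter) from compound 1 to compound 2 and a 1.3-fold higher number (0.11 log units; within the scatter) from compound 3 to compound 4, 1.4-fold (0.14 log units) apart, within the scatter of two such steps. Among these compounds, this shows only that the swap leaves the read-out unresolved on both cores; neither step has a direction that can be trusted, so it does not show that a real effect of this change transfers from one core to the other, and one pair of groups on two cores supports no wider rule.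

The compounds shown carry only the two aromatic groups on the sulfur, so it stays open whether a simple alkyl chain, a benzyl group or a chain ending in an amine or a carboxylic acid would move the number beyond the scatter. On these data alone, it also stays open whether such a group would then act alike on both cores.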